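A few compounds are considered here, and "the series" means these few. Any claim that something is new, unique, unknown or untested is made for them only; others in the source may bear on it.

Working notes on the anilide series sharing the core of compound 1 `O=C(CSc1nc(Nc2ccccc2)c2ccccc2n1)Nc1cccc(F)c1`. In a functional assay on MGC-803 cells (Homo sapiens) for inhibition, read by MTT assay, with a stated time of 72 h (a lower number here means a stronger inhibitor, a higher number a weaker inhibitor), compound 1 gives 12700 nM. Among the three measured compounds this number is the second highest: compound 3 `COc1cccc(NC(=O)CSc2nc(Nc3ccccc3)c3ccccc3n2)c1`, with 10000 nM, stands nearest, and the gap a 1.3-fold lower number from compound 1 to compound 3 (0.10 log units; within the scatter) lies within the scatter, whereas compound 2 `O=C(CSc1nc(Nc2ccccc2)c2ccccc2n1)Nc1cccc([N+](=O)[O-])c1`, with 28100 nM, stands furthest, the step of a 2.2-fold higher number from compound 1 to compound 2 (0.34 log units; beyond the scatter) being beyond the scatter. Between the two outer compounds the step of a 2.8-fold lower number from compound 2 to compound 3 (0.45 log units; beyond the scatter) is also modest.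

Compound 4 `O=C(CSc1nc(Nc2ccccc2)c2ccccc2n1)Nc1ccc(C(F)(F)F)cc1` is not yet measured. It differs from compound 1 by 4-(trifluoromethyl)phenyl in place of 3-fluorophenyl on an amide-type nitrogen. Among the measured compounds shown here, no measured step makes this same change; the three steps that do exist all exchange one group on the aryl amide and span only a modest range, from within the scatter to a modest shift. On that basis a step of at most modest size is expected in this assay, without a clear direction. Compound 4 is therefore estimated at 12000 nM, with a range of 4500 nM to 32000 nM, meaning an expected step of a 1.1-fold lower number from compound 1 to compound 4 (0.02 log units; within the scatter).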

Compound 4, half-maximal inhibitory concentration: 8670 nM
The estimate for compound 4 lay 1.4-fold (0.14 log units) above the measured number; low and high end bracket the measured number.
By their numbers in this assay, from the lowest: compounds 4, 3 and 1 (each within the scatter of the next); then compound 2.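

Compound 4 carries a larger group on the amide-type nitrogen, 4-(trifluoromethyl)phenyl with 10 heavy atoms against 7 in 3-fluorophenyl, and in this assay this exchange stays within the scatter: a 1.5-fold lower number from compound 1 to compound 4 (0.17 log units; within the scatter) and a 1.2-fold lower number from compound 3 to compound 4 (0.06 log units; within the scatter). Among the compounds shown here, compound 2 stands apart, with a 3.2-fold lower number from compound 2 to compound 4 (0.51 log units; beyond the scatter), and its 3-nitrophenyl is the only one of the four groups whose steps to all the others lie beyond the scatter. No measurement shown bears on why the numbers fall as they do.

The step from compound 1 to compound 4 changes the group and its place on the ring together, and a 3-(trifluoromethyl)phenyl or 4-fluorophenyl group would separate the two. Also open, going by these compounds, is how an amine or a carboxylic acid on this aryl ring would read, or a longer chain in place of the aryl group.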